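The compounds below may be only part of what the source reports. "The series", "measured", "known", "first", "only" and "open" are said of these compounds alone.

For the measured compounds named here, compound 2, with structure `CCCCC(C)(C)OC(=O)CC(=O)Nc1c(C(C)C)cccc1C(C)C`, gives 15 nM in an assay on microsomes from intestine for inhibition of acyl-CoA:cholesterol acyltransferase (Oryctolagus cuniculus) (on this read-out lower numbers stand for stronger inhibition and higher numbers for weaker inhibition), and this is the only number given among the two values shown. Compound 1, with structure `CC(C)c1cccc(C(C)C)c1NC(=O)CC(=O)O`, reaches only a limit of the assay in this assay, > 5000 nM. Going by the values given here, the step between them, an at least 330-fold lower number from compound 1 to compound 2 (2.52 log units; beyond the scatter), is the single measured step, and it rests on (the limit of > 5000 nM in this assay, at which 1 of the 2 values shown sits). Compound 3, with structure `CCCCCCCCCCCCC(C)(C)OC(=O)CC(=O)Nc1c(C(C)C)cccc1C(C)C`, differs from compound 2 by octyl in place of hydrogen on a saturated chain carbon, five bonds along the chain from an oxygen next to a carbonyl group. Among the compounds with values here, no measured step touches the length of this chain; the one measured step replaced a hydrogen on the oxygen with the whole 1,1-dimethylpentyl group, and compound 3 keeps that ester in place. The expectation is therefore a step no larger than the scatter, in either direction, written as no change at the digits printed from compound 2 to compound 3 (within the scatter). Compound 3 is thus estimated at 15 nM, with a range from 4 nM to 60 nM in this assay.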

Compound 3, half-maximal inhibitory concentration: 12 nM
Compound 3: the middle estimate sits 1.3-fold (0.10 log units) above what was measured, and the stated range covers the measured number.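

With octyl in place of hydrogen on this saturated chain carbon, this assay shows a 1.3-fold lower number from compound 2 to compound 3 (0.10 log units; within the scatter) and nothing more. The earlier pair showed only that adding the whole 1,1-dimethylpentyl group to the oxygen matters a great deal, whereas compound 3 adds that the far end of this chain can carry 8 further carbon atoms with no change beyond the scatter. The data given offer no explanation for why the longer chain leaves the reading in place.

The compounds shown leave open whether in this assay a shorter chain, a chain of intermediate length or a still longer chain would read the same. They also leave open what a hydroxyl group, an amine or a carboxylic acid at the end of the chain would do, or a phenyl ring in place of octyl.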